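Replacing Cyclobutylamino with 2,6-Dimethylmorpholin-4-yl on the Amide

The compounds below may be only part of what the source reports. "The series", "measured", "known", "first", "only" and "open" are said of these compounds alone.

Compound 1 `CNC(=O)/C(C)=C/c1ccc(NC(=O)Nc2ccc(Cl)c(C(F)(F)F)c2)cc1` gives only a limit in a functional assay on MX1 cells (Homo sapiens) for inhibition, read by MTT assay, with a stated time of 120 h; on this read-out lower numbers stand for stronger inhibition and higher numbers for weaker inhibition: > 50000 nM.
Compound 2 `O=C(CCc1ccc(NC(=O)Nc2ccc(Cl)c(C(F)(F)F)c2)cc1)NC1CCC1` gives 24000 nM in this assay.
Compound 3 `O=C(/C=C/c1ccc(NC(=O)Nc2ccc(Cl)c(C(F)(F)F)c2)cc1)NC1CCC1` gives 4530 nM in this assay.

Of the two numbers, compound 2 sits highest; the nearest neighbour is compound 3, reached by a 5.3-fold lower number from compound 2 to compound 3 (0.72 log units; beyond the scatter). Compound 1 stands apart, since the limit of > 50000 nM in this assay, at which 1 of the 3 values shown sits, is a limit and not a number.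

Compound 4 `CC1CN(C(=O)CCc2ccc(NC(=O)Nc3ccc(Cl)c(C(F)(F)F)c3)cc2)CC(C)O1` has not yet been measured. It differs from compound 2 in one place: 2,6-dimethylmorpholin-4-yl in place of cyclobutylamino on a carbonyl carbon. With that change the amide loses its hydrogen-bond donor.

Going by the values given here, no measured step changes only the group on the amide nitrogen. The step of an at least 2.0-fold lower number from compound 1 to compound 2 (0.31 log units; beyond the scatter) alters that group together with the chain, and a 5.3-fold lower number from compound 2 to compound 3 (0.72 log units; beyond the scatter) alters the chain alone, so neither speaks directly to the change in compound 4. Both, however, show this position to be sensitive to moderate changes. The expectation is therefore a step of modest size, more likely towards a higher number, given as a 1.5-fold higher number from compound 2 to compound 4 (0.16 log units; within the scatter). Compound 4 is estimated to give 35000 nM in this assay, within a range from 9000 nM to 120000 nM.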

Compound 4, half-maximal inhibitory concentration: > 50000 nM
Compound 4: no number, only a limit (the forecaster's own chance of this, stated with the estimate: 30%); middle value at least 1.4-fold (0.15 log units) from the limit.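

This is the only step shown that changes the group on the amide nitrogen and nothing else. In this assay, putting 2,6-dimethylmorpholin-4-yl in place of cyclobutylamino on the carbonyl carbon weakens inhibition, with an at least 2.0-fold higher number from compound 2 to compound 4 (0.31 log units; beyond the scatter). On these data alone, since compound 4 gives a limit and not a number, this step shows only a minimum size, and the full loss stays unknown. The group on the amide nitrogen therefore matters on its own, apart from the chain, and compound 4 joins compound 1 at the end of what this read-out reports: the limit of > 50000 nM in this assay, at which 2 of the 4 values shown sit.

The change alters the ring and removes the amide hydrogen in one move, so the compounds shown cannot say which of these accounts for the loss. As far as these compounds go, a plain morpholin-4-yl group without the two methyl groups, or a cyclopentylamino group that keeps the amide hydrogen, would help to separate the two, and how 2,6-dimethylmorpholin-4-yl behaves on the 2-carbamoylethenyl chain of compound 3 also remains open.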